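Urea series on a shared core: expectation for compound 4

The compounds below may be only part of what the source reports. "The series", "measured", "known", "first", "only" and "open" are said of these compounds alone.

Measured in a functional assay on HepG2 cells (Homo sapiens) for antiproliferative activity, read by MTT assay, with a stated time of 48 h (a lower number here means a stronger inhibitor, a higher number a weaker inhibitor), so far:
- compound 1 `Cc1ccc(NC(=O)Nc2cccc(CNc3nccnc3Cl)c2)cc1Cl` gives 11300 nM
- compound 2 `O=C(Nc1cccc(CNc2nccnc2Cl)c1)Nc1ccc(Cl)cc1Br` gives 6720 nM
- compound 3 `O=C(Nc1cccc(CNc2nccnc2Cl)c1)NC1CCCC1` gives 18400 nM

Compound 3 holds the highest of the three numbers. Its gap to compound 1 is small: a 1.6-fold higher number from compound 1 to compound 3 (0.21 log units; within the scatter). Its gap to compound 2 is larger: a 2.7-fold higher number from compound 2 to compound 3 (0.44 log units; beyond the scatter).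

Compound 4 `COc1ccccc1NC(=O)Nc1cccc(CNc2nccnc2Cl)c1` is the next member. Relative to compound 3 the change is 2-methoxyphenyl in place of cyclopentyl on an amide-type nitrogen. The two steps that bear on it are the ones that reach compound 3 from compound 1 and from compound 2, since each of those replaces a substituted phenyl on the same amide-type nitrogen with cyclopentyl; compound 4 runs that exchange the other way. One of those steps sat within the scatter and the other was modest, so a lower number for compound 4 in this assay is expected, of modest size at most, and the expected step is a 1.9-fold lower number from compound 3 to compound 4 (0.29 log units; within the scatter). Compound 4 is therefore estimated at 9500 nM, with a range from 4500 nM to 20000 nM.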

Compound 4, half-maximal inhibitory concentration: 13700 nM
Compound 4: the middle estimate sits 1.4-fold (0.16 log units) below what was measured; low and high end bracket the measured number.
By their numbers in this assay, from the lowest: compounds 2, 1, 4 and 3 (each within the scatter of the next, the first and the last beyond it).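

In this assay, 2-methoxyphenyl is the only group shown on this amide-type nitrogen that brings oxygen and a hydrogen-bond acceptor, yet its exchange for cyclopentyl stays within the scatter (a 1.3-fold lower number from compound 3 to compound 4 (0.13 log units; within the scatter)), and so does its exchange for 3-chloro-4-methylphenyl (a 1.2-fold higher number from compound 1 to compound 4 (0.08 log units; within the scatter)). Only the comparison with 2-bromo-4-chlorophenyl passes the scatter (a 2.0-fold higher number from compound 2 to compound 4 (0.31 log units; beyond the scatter)), so compound 2 now stands apart from both compound 3 and compound 4, although compound 1 goes against any general separation of the halogenated aryl ureas from the rest. No measurement shown here offers a reason for these steps.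

From the compounds shown here alone, whether unsubstituted phenyl on this nitrogen would match compound 4 remains open, so the contribution of the methoxy group cannot be separated from that of the aromatic ring. Also open, going by these compounds, is whether an amine or a carboxylic acid at this place would leave the number in the same range.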